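Changing the group on the aromatic nitrogen

The source may hold more compounds than are shown below. What is called first, only, known or untested is meant among the compounds shown, and "the series" means these compounds.

compound 1 `Cc1c(Oc2c(F)cccc2F)c(OC(C)C)nn1-c1ccc(C2CC2)cn1`: 0.1 h
compound 2 `Cc1c(Oc2c(F)cccc2F)c(OC(C)C)nn1-c1ncc(Br)cc1F`: 1 h

Among the compounds with values here, in an ADME assay on microsomes (Homo sapiens) for metabolic stability (on this read-out lower numbers stand for a shorter-lived compound and higher numbers for a longer-lived compound), compound 2 stands at 1 h, the higher of the two numbers measured so far. Compound 3 `COc1ccc(-n2nc(OC(C)C)c(Oc3c(F)cccc3F)c2C)nn1` has 6-methoxypyridazin-3-yl in place of 5-bromo-3-fluoropyridin-2-yl on an aromatic nitrogen. Within the data shown here, one measured step bears on this change, since it swaps the group on that same nitrogen: a 10-fold higher number from compound 1 to compound 2 (1.00 log units; beyond the scatter). That step lies beyond the scatter and shows that this group can matter in this assay. However, neither measured compound carries the entering group, so the direction remains uncertain. With compound 2 at 1 h, the top of the small measured range, a moderate fall seems more likely than a further rise. The expected change is a 2.5-fold lower number from compound 2 to compound 3 (0.40 log units; beyond the scatter). For compound 3 the estimate is 0.4 h, with an expected range from 0.12 h to 1.3 h.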

Compound 3, half-life: 0.367 h
Compound 3: the middle estimate sits 1.1-fold (0.04 log units) above what was measured, within the range that was stated.
By their numbers in this assay, from the lowest: compound 1; then compound 3; then compound 2.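

In this assay the swap to 6-methoxypyridazin-3-yl gives a 2.7-fold lower number from compound 2 to compound 3 (0.44 log units; beyond the scatter) and yet a 3.7-fold higher number from compound 1 to compound 3 (0.56 log units; beyond the scatter) when set against 5-cyclopropylpyridin-2-yl, so this group lands between the two earlier ones. Compound 3 carries neither bromine nor fluorine on this ring, so among these three compounds, a number higher than that of compound 1 does not depend on those two atoms. Nothing available here explains why the number moves with the group on this nitrogen. The step changes the ring and its substituent together, so the part played by the second ring nitrogen cannot be separated from that of the methoxy group. Going by these compounds, how a morpholine or a carboxylic acid on this ring would behave also remains open.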